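The compounds below may be only part of what the source reports. "The series", "measured", "known", "first", "only" and "open" are said of these compounds alone.

Working notes on the series. For the measured compounds named here, compound 2 `Cc1nn(C)c(C)c1-c1ccc(-c2nnc(N(C)Cc3ccc4nccn4c3)o2)c(Cl)c1` gives 2.51 nM in an assay on isolated protein for inhibition of tyrosine-protein kinase Mer (Homo sapiens), read by LC-MS (on this read-out lower numbers stand for stronger inhibition and higher numbers for weaker inhibition), and has the lowest number of the two measured so far; its nearest neighbour is compound 1 `Cc1nn(C)c(C)c1-c1ccc(-c2nnc(N(C)Cc3ccc4nccn4c3)o2)c(F)c1`, which in this assay gives 12.6 nM. Going by the values given here, the only step measured is a 5.0-fold lower number from compound 1 to compound 2 (0.70 log units; beyond the scatter), a change at the same aromatic carbon that is altered again here. Compound 3 `COc1cc(-c2c(C)nn(C)c2C)ccc1-c1nnc(N(C)Cc2ccc3nccn3c2)o1` differs from compound 2 by methoxy in place of chloro on an aromatic carbon. That step bears on the present change only loosely, since it compares two halogens, whereas methoxy is neither; it does show that this position is sensitive to what sits on it. Among the compounds with values here, with no measured methoxy analogue, the expected step is a modest move toward a higher number, likely within or just beyond the scatter, estimated as a 2.4-fold higher number from compound 2 to compound 3 (0.38 log units; beyond the scatter). Compound 3 is therefore estimated at 6 nM in this assay, with a range of 1.5 nM to 25 nM.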

Compound 3, half-maximal inhibitory concentration: 15.9 nM
Compound 3: the middle estimate sits 2.7-fold (0.42 log units) below what was measured; the range from low to high includes it.
By their numbers in this assay, from the lowest: compound 2; then compounds 1 and 3 (each within the scatter of the next).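

In this assay the step of a 6.3-fold higher number from compound 2 to compound 3 (0.80 log units; beyond the scatter) shows that the number at this aromatic carbon does not depend on chloro versus fluoro alone, since methoxy also gives a result separated from chloro. The step of a 1.3-fold higher number from compound 1 to compound 3 (0.10 log units; within the scatter) leaves methoxy and fluoro unseparated, so the three compounds do not split into halogens against a non-halogen: compound 1 carries a halogen yet sits with compound 3, and only compound 2 stands apart. No measurement is available to explain why chloro separates from the other two groups.

From the compounds shown here alone, whether bromo, methyl or an amine on this aromatic carbon would sit with chloro or with fluoro and methoxy stays open. Also open, going by these compounds, is whether the same separation holds with another group in place of the 1,3,5-trimethyl-1H-pyrazol-4-yl group.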